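Pyrazole for chlorophenyl in a quinazolinone acetamide series

The compounds below may be only part of what the source reports. "The series", "measured", "known", "first", "only" and "open" are said of these compounds alone.

Compound 2 `C[C@H](NC(=O)Cn1nnc2ccccc2c1=O)c1ccc(Cl)cc1` is the reference here. In an ADME assay on microsomes from liver (Homo sapiens) for metabolic stability (a lower number here means slower removal, a higher number faster removal of the compound), compound 2 gives < 9.9 mL/min/kg, which is a limit of the assay and not a number. Compound 1 `CC(NC(=O)Cn1nnc2ccccc2c1=O)c1ccc(Cl)cc1` is the same substance drawn without configuration at one stereocentre, and in this assay compound 1 gives < 9.9 mL/min/kg, again a limit. The step that the two limits leave unreadable from compound 1 to compound 2 is therefore not readable, as the limit of < 9.9 mL/min/kg in this assay, at which 2 of the 3 values shown sit, and the fact that one of compounds 1 and 2 is drawn with a defined configuration and the other without, at the place where they differ make plain. Going by the values given here, compound 3 `COc1ccc([C@H](C)NC(=O)Cn2nnc3ccccc3c2=O)c(OC)c1` carries a different aryl group, and in this assay compound 3 gives 24 mL/min/kg; no single-point step connects it to compound 2.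

Compound 4 `C[C@H](NC(=O)Cn1nnc2ccccc2c1=O)c1ccn(C)n1` differs from compound 2 by 1-methyl-1H-pyrazol-3-yl in place of 4-chlorophenyl on a saturated chain carbon bound to an amide-type nitrogen and a saturated chain carbon. Among the compounds with values here, no measured step covers this change, and the one pair that differs in a single place sits at the limit on both sides. The expected step of an at least 1.2-fold higher number from compound 2 to compound 4 (0.08 log units; that floor lies within the scatter) is therefore uncertain, with the reading for compound 4 estimated at 12 mL/min/kg, between 5 mL/min/kg and 30 mL/min/kg.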

Compound 4, clearance: 12 mL/min/kg
Compound 4: middle estimate and measured number agree at the digits printed; low and high end bracket the measured number.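

In this assay compound 4 gives 12 mL/min/kg as a number and not a limit, so this position on a saturated chain carbon bound to an amide-type nitrogen and a saturated chain carbon now has a readable result with a five-membered aromatic ring in place of 4-chlorophenyl. The swap to 1-methyl-1H-pyrazol-3-yl amounts to an at least 1.2-fold higher number from compound 2 to compound 4 (0.08 log units; that floor lies within the scatter) and, as that floor lies within the scatter, no real change in clearance is established. Going by these compounds, the true size of the step stays unknown because of the assay limit on compound 2: the limit of < 9.9 mL/min/kg in this assay, at which 2 of the 4 values shown sit.

On these data alone, whether a pyrazole without the methyl group would read as a number or at the limit stays open. So does the reading of a pyridine or an unsubstituted phenyl at this position.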